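Changing the Group on the Carbonyl Carbon

The source may hold more compounds than are shown below. What is called first, only, known or untested is meant among the compounds shown, and "the series" means these compounds.

Compound 1 `COc1cc(-c2nnc(SCC(=O)c3ccc(F)cc3)n2N)cc(OC)c1OC` gives 20900 nM in a functional assay on HeLa cells (Homo sapiens) for antiproliferative activity, read by MTT assay, with a stated time of 48 h; a higher number here means a weaker inhibitor, a lower number a stronger inhibitor.
Compound 2 `COc1cc(-c2nnc(SCC(=O)c3ccc(F)c(F)c3)n2N)cc(OC)c1OC` gives > 100000 nM, which is a limit of this assay (the limit of > 100000 nM in this assay, at which 1 of the 3 values shown sits).
Compound 3 `COc1ccc(C(=O)CSc2nnc(-c3cc(OC)c(OC)c(OC)c3)n2N)cc1` gives 17400 nM.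

Compound 3 holds the lowest of the two plain numbers, but compound 1 sits within the usual scatter of it. Compound 4 `COc1cc(-c2nnc(SCC(=O)Nc3ccccc3F)n2N)cc(OC)c1OC` differs from compound 3 in one place: (2-fluorophenyl)amino in place of 4-methoxyphenyl on a carbonyl carbon. The measured steps that touch the group on the carbonyl carbon only swap one aryl group for another: a 1.2-fold lower number from compound 1 to compound 3 (0.08 log units; within the scatter) and an at least 5.7-fold lower number from compound 2 to compound 3 (0.75 log units; beyond the scatter). None of them exchanges a carbon link for an amino link, so the change to compound 4 is not covered by any measured step. The expected step of a 1.4-fold higher number from compound 3 to compound 4 (0.16 log units; within the scatter) is therefore taken as none clearly beyond the scatter, with wide uncertainty. Compound 4 is estimated at 25000 nM, within 7000 nM to 100000 nM.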

Compound 4, half-maximal inhibitory concentration: 38200 nM
Compound 4: the middle estimate sits 1.5-fold (0.18 log units) below what was measured; measured number inside the range.
By their numbers in this assay, from the lowest: compounds 3, 1 and 4 (each within the scatter of the next, the first and the last beyond it). At a limit, above all of these: compound 2.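

An amino link on the carbonyl carbon keeps measurable activity in this assay, with a modest loss against the 4-methoxyphenyl group, a 2.2-fold higher number from compound 3 to compound 4 (0.34 log units; beyond the scatter), and no change beyond the scatter against the 4-fluorophenyl group, a 1.8-fold higher number from compound 1 to compound 4 (0.26 log units; within the scatter). The new group also compares favourably with the 3,4-difluorophenyl group, an at least 2.6-fold lower number from compound 2 to compound 4 (0.41 log units; beyond the scatter). The value of compound 2 is a limit: the limit of > 100000 nM in this assay, at which 1 of the 4 values shown sits.

As far as these compounds go, the link and the ring substituent change together here, so the share of each stays open. A (4-methoxyphenyl)amino group on the same carbonyl carbon would separate the two.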